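Series notes: methoxy substitution on the aryl ring

This account rests on a few compounds, and the source may have more. Where it says the series, first, only, none or still open, it means among the compounds named here.

Measured so far:
compound 1 `C[C@@H](NS(=O)(=O)N1CCC(c2ccc(Cl)cc2)CC1)C(=O)NO` — 5800 nM
compound 2 `O=C(NO)[C@H]1CCCCN1S(=O)(=O)N1CC=C(c2ccccc2)CC1` — 240 nM
compound 3 `O=C(NO)[C@H]1CCCCN1S(=O)(=O)N1CC=C(c2ccc(F)cc2)CC1` — 300 nM

In a functional assay on MONO-MAC-6 cells (Homo sapiens) for inhibition (on this read-out higher numbers stand for weaker inhibition and lower numbers for stronger inhibition), compound 2 gives the lowest number of the three. Compound 3 sits nearest, and the step of a 1.3-fold higher number from compound 2 to compound 3 (0.10 log units; within the scatter) lies within the scatter, so no order between compound 2 and compound 3 can be read from these two values. Within the data shown here, compound 1, which differs from compound 2 in several places at once, gives a number far higher, well beyond the scatter; no single-point step connects it to compound 2.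

Compound 4 `COc1cccc(C2=CCN(S(=O)(=O)N3CCCC[C@@H]3C(=O)NO)CC2)c1` is not yet measured. It differs from compound 2 by methoxy in place of hydrogen on an aromatic carbon. Among the measured compounds shown here, no measured step introduces a methoxy group on this ring. For the measured compounds named here, the only change measured on an aromatic carbon of the ring is a 1.3-fold higher number from compound 2 to compound 3 (0.10 log units; within the scatter), which stayed within the scatter. The series gives no basis for expecting a move beyond the scatter in either direction, so the expected step of a 1.3-fold higher number from compound 2 to compound 4 (0.10 log units; within the scatter) is small. Compound 4 is therefore estimated at 300 nM, with an expected range from 120 nM to 800 nM.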

Compound 4, half-maximal inhibitory concentration: 260 nM
Compound 4: the middle estimate sits 1.2-fold (0.06 log units) above what was measured; low and high end bracket the measured number.
By their numbers in this assay, from the lowest: compounds 2, 4 and 3 (each within the scatter of the next); then compound 1.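

In this assay, among these compounds, methoxy on an aromatic carbon, meta to a large group, leaves the read-out where it was, with a 1.1-fold higher number from compound 2 to compound 4 (0.03 log units; within the scatter), so this ring carbon accepts a group with heavy atoms and an oxygen, where the earlier compounds showed only the fluoro change. The exchange of 4-fluorophenyl for 3-methoxyphenyl gives a 1.2-fold lower number from compound 3 to compound 4 (0.06 log units; within the scatter), so phenyl, 4-fluorophenyl and 3-methoxyphenyl cannot be ordered on this read-out. No supporting data bear on why these aryl changes leave the number so flat.

As far as these compounds go, whether an amine, a carboxylic acid or a longer alkoxy chain on this ring carbon would move the number beyond the scatter stays open. The distance to compound 1 at 5800 nM also remains unassigned, as that compound differs in several places at once.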